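Aryl variation on the shared core: estimate for compound 4

The source may report more compounds than this note shows. Statements on the series, on what has been measured and on what is new or still open speak of the compounds shown alone.

Measured in a functional assay on HeLa cells (Homo sapiens) for inhibition, read by cell counting, with a stated time of 4 days; a lower number here means a stronger inhibitor, a higher number a weaker inhibitor:
compound 1 `C=C(Br)C(=O)Nc1cccc(-c2cn3nc(-c4ccc(F)cc4)sc3n2)c1` — 870 nM
compound 2 `C=C(Br)C(=O)Nc1cccc(-c2cn3nc(-c4ccccc4)sc3n2)c1` — 1400 nM
compound 3 `C=C(Br)C(=O)Nc1cccc(-c2cn3nc(-c4ccc(OC)c(OC)c4)sc3n2)c1` — 610 nM

Compound 3 gives the lowest of the three numbers; compound 1 is nearest, and the two lie within the scatter of each other, while compound 2 is furthest. Compound 4 `C=C(Br)C(=O)Nc1cccc(-c2cn3nc(-c4ccc(Cl)cc4)sc3n2)c1` is not yet measured. Its change from compound 3: 4-chlorophenyl in place of 3,4-dimethoxyphenyl on an aromatic carbon. Going by the values given here, two measured steps bear on the same exchange of aryl group: a 1.4-fold lower number from compound 1 to compound 3 (0.15 log units; within the scatter) and a 2.3-fold lower number from compound 2 to compound 3 (0.36 log units; beyond the scatter). Both run toward compound 3, one within the scatter and one modest. Among the compounds with values here, no step to a 4-chlorophenyl exists; the closest reference is compound 1 with 4-fluorophenyl at 870 nM, and compound 2 with plain phenyl at 1400 nM. Compound 4 is expected to sit near compound 1, so the step to compound 4 is expected to be small and upward, probably within the scatter: a 1.4-fold higher number from compound 3 to compound 4 (0.14 log units; within the scatter). Estimate for compound 4: 850 nM, range 420 nM to 1700 nM.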

Compound 4, half-maximal inhibitory concentration: 3000 nM
Beside the measured number, compound 4's estimate is 3.5-fold (0.55 log units) below it, and the stated range ends below it.
By their numbers in this assay, from the lowest: compounds 3, 1 and 2 (each within the scatter of the next, the first and the last beyond it); then compound 4.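

In this assay, this aryl position distinguishes the two halogens: chloro in place of fluoro raises the number (a 3.4-fold higher number from compound 1 to compound 4 (0.54 log units; beyond the scatter)), whereas compound 1 and compound 2, with fluoro and hydrogen, lie within the scatter of each other. Chloro in place of hydrogen also raises it (a 2.1-fold higher number from compound 2 to compound 4 (0.33 log units; beyond the scatter)), so 4-chlorophenyl does not group with 4-fluorophenyl and phenyl, and its exchange with 3,4-dimethoxyphenyl gives the largest step in the set (a 4.9-fold higher number from compound 3 to compound 4 (0.69 log units; beyond the scatter)). Nothing available explains why the two halogens part here.

On these data alone, it remains open whether a bromo or methyl group on the same phenyl ring would track compound 4 or compound 1. Also open, as far as these compounds go, is whether a single methoxy group, or an amine, would give a number closer to compound 3 than to compound 4.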